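The compounds below may be only part of what the source reports. "The series", "measured", "known", "first", "only" and "open" are said of these compounds alone.

In an ADME assay on THP-1 cells (Homo sapiens) for cytotoxicity (a lower number here means a stronger inhibitor, a higher number a weaker inhibitor), compound 2 `COc1ccccc1-c1nnc(-c2ccc(C(=O)N/N=C/c3ccccc3O)cc2)o1` gives 207000 nM, while compound 1 `COc1ccccc1-c1nnc(-c2ccc(C(=O)N/N=C/c3cccc(F)c3)cc2)o1` gives 353000 nM. Compound 2 stands lowest of the two numbers, but the step of a 1.7-fold lower number from compound 1 to compound 2 (0.23 log units; within the scatter) lies within the scatter. Compound 3 `COc1ccccc1-c1nnc(-c2ccc(C(=O)N/N=C/c3cccnc3)cc2)o1` differs from compound 2 by pyridin-3-yl in place of 2-hydroxyphenyl on a carbon with a double bond to nitrogen. For the measured compounds named here, the only measured step that bears on exchanging this ring is the one from compound 1 to compound 2, and it stayed within the scatter, so for compound 3 no step beyond the scatter is expected: a 1.2-fold higher number from compound 2 to compound 3 (0.08 log units; within the scatter). Compound 3 is therefore estimated at 250000 nM, in a range from 100000 nM to 600000 nM.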

Compound 3, half-maximal inhibitory concentration: 167000 nM
Beside the measured number, compound 3's estimate is 1.5-fold (0.18 log units) above it; the measured number falls inside the stated range.
By their numbers in this assay, from the lowest: compounds 3, 2 and 1 (each within the scatter of the next, the first and the last beyond it).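

In this assay, pyridin-3-yl in place of 2-hydroxyphenyl gives a 1.2-fold lower number from compound 2 to compound 3 (0.09 log units; within the scatter), so a ring with a hetero atom is tolerated here as well as the two carbon-only rings. Against 3-fluorophenyl, the same group gives a 2.1-fold lower number from compound 1 to compound 3 (0.33 log units; beyond the scatter), the first step at this position to pass the scatter, though only modestly. No supporting measurement explains this difference. On these data alone, all three groups are six-membered aromatic rings, so it remains open how far the number would move with a carboxylic acid, an amine or a longer chain on the carbon with a double bond to nitrogen.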